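This account rests on a few compounds, and the source may have more. Where it says the series, first, only, none or still open, it means among the compounds named here.

Measured compounds:
- compound 1 `N#Cc1ccc(N[C@@H]2CN[C@H](C(=O)N3CCSC3)C2)cc1`, which in an assay on a cell-free system (plasma) for inhibition of Dipeptidyl peptidase 4 (Rattus norvegicus), read by fluorescence (a higher number here means a weaker inhibitor, a lower number a stronger inhibitor), gives 33.6 nM
- compound 2 `O=C(Nc1ccccc1)N[C@@H]1CN[C@H](C(=O)N2CCSC2)C1`, which in this assay gives 151 nM
- compound 3 `CN(Cc1ccc(C#N)cc1)[C@@H]1CN[C@H](C(=O)N2CCSC2)C1`, which in this assay gives 13.6 nM

Compound 3 holds the lowest number of the three. Its nearest neighbour is compound 1, whose number is higher by a margin beyond the usual scatter, and compound 2 stands furthest away, also beyond the scatter. No pair among these three differs in a single place, so no single-change step can be read from them.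

Compound 4 `CCOC(=O)CN(Cc1ccc(C#N)cc1)[C@@H]1CN[C@H](C(=O)N2CCSC2)C1` has not yet been measured in this assay. Relative to compound 3 it carries one change: ethoxycarbonyl in place of hydrogen on a saturated chain carbon bound to an amine nitrogen. For the measured compounds named here, nothing among the measured compounds tests this kind of addition, so the expectation rests on the general observation that the shared core tolerates varied groups on that amine nitrogen. A small step toward a weaker inhibitor, within the scatter, is expected, read as a 1.8-fold higher number from compound 3 to compound 4 (0.26 log units; within the scatter). Compound 4 is therefore estimated at 25 nM, with a range from 8 nM to 80 nM.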

Compound 4, half-maximal inhibitory concentration: 15.3 nM
For compound 4 the middle estimate is 1.6-fold (0.21 log units) above the measured one, within the range that was stated.
By their numbers in this assay, from the lowest: compounds 3 and 4 (each within the scatter of the next); then compound 1; then compound 2.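

In this assay, the step gives a 1.1-fold higher number from compound 3 to compound 4 (0.05 log units; within the scatter), so the methyl of compound 3 can become the (ethoxycarbonyl)methyl of compound 4, with 5 heavy atoms and 2 hydrogen-bond acceptors entering, and the number stays within the scatter. For the compounds shown here, the earlier compounds differed from one another in more than one place, so this is the first direct reading of a single change at this saturated chain carbon bound to an amine nitrogen. No measurement shown gives a reason for this result.

A single step cannot show whether this position would accept other groups in the same way, such as a carboxylic acid, an amine or a longer chain. It also leaves open whether ethoxycarbonyl itself matters here, or whether a smaller group such as hydroxymethyl would read the same.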